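Swapping the Aryl Ketone: Dimethylphenyl to Fluorophenyl

The source may hold more compounds than are shown below. What is called first, only, known or untested is meant among the compounds shown, and "the series" means these compounds.

Measured so far:
- compound 1, `COc1ccc(/C=C/c2cc(OC)cc(OC)c2/C=C/C(=O)c2ccc(Cl)c(Cl)c2)cc1`: 5.9 ug/mL
- compound 2, `CCCC(C)Oc1ccc(C(=O)/C=C/c2c(/C=C/c3ccc(OC)cc3)cc(OC)cc2OC)cc1`: 9.4 ug/mL
- compound 3, `COc1ccc(/C=C/c2cc(OC)cc(OC)c2/C=C/C(=O)c2ccc(C)cc2C)cc1`: 0.3 ug/mL

All three share one core and differ only in the aromatic group on the carbonyl carbon. In a functional assay on A549 cells (Homo sapiens) for antiproliferative activity, read by MTT assay, with a stated time of 48 h (on this read-out lower numbers stand for stronger inhibition and higher numbers for weaker inhibition), compound 3 gives the lowest number of the three. Both steps leading to it, a 20-fold lower number from compound 1 to compound 3 (1.29 log units; beyond the scatter) and a 31-fold lower number from compound 2 to compound 3 (1.50 log units; beyond the scatter), lie beyond the scatter, so compound 3 is the most potent compound measured here, while compound 1 and compound 2 sit within the scatter of each other.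

Compound 4, `COc1ccc(/C=C/c2cc(OC)cc(OC)c2/C=C/C(=O)c2ccc(F)cc2)cc1`, is not yet measured. It differs from compound 3 by 4-fluorophenyl in place of 2,4-dimethylphenyl on a carbonyl carbon. Going by the values given here, no measured step involves a 4-fluorophenyl, so the only guide is indirect: every measured departure from 2,4-dimethylphenyl on the carbonyl carbon raised the number by a large amount, and a further departure is expected to do the same, though the size is uncertain because a 20-fold lower number from compound 1 to compound 3 (1.29 log units; beyond the scatter) and a 31-fold lower number from compound 2 to compound 3 (1.50 log units; beyond the scatter) concern different groups. Compound 4 is therefore expected to give 3 ug/mL, within a range from 0.8 ug/mL to 12 ug/mL. The expected step is a 10-fold higher number from compound 3 to compound 4 (1.00 log units; beyond the scatter).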

Compound 4, half-maximal inhibitory concentration: 6.6 ug/mL
Compound 4: the middle estimate sits 2.2-fold (0.34 log units) below what was measured; low and high end bracket the measured number.
By their numbers in this assay, from the lowest: compound 3; then compounds 1, 4 and 2 (each within the scatter of the next).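

With 4-fluorophenyl, a third group has now taken the place of 2,4-dimethylphenyl on the carbonyl carbon in this assay, and the outcome is again a large rise, a 22-fold higher number from compound 3 to compound 4 (1.34 log units; beyond the scatter). The other two comparisons, a 1.1-fold higher number from compound 1 to compound 4 (0.05 log units; within the scatter) and a 1.4-fold lower number from compound 2 to compound 4 (0.15 log units; within the scatter), both lie within the scatter, so 4-fluorophenyl, 3,4-dichlorophenyl and 4-(1-methylbutoxy)phenyl cannot be told apart here, and compound 3 alone stands out as the most potent of the four. Nothing available here explains why the 2,4-dimethylphenyl group stands apart.

The compounds shown leave open whether both methyl groups of 2,4-dimethylphenyl are needed, or whether a phenyl carrying one methyl would do as well. On these data alone, it also remains open whether larger alkyl groups, such as two ethyl groups, or a phenyl carrying an amine or a carboxylic acid, would keep the low number of compound 3.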